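The compounds below may be only part of what the source reports. "The series", "measured", "known", "first", "only" and "open" are said of these compounds alone.

In a functional assay on A2780 cells (Homo sapiens) for cytotoxicity, read by sulforhodamine B assay, with a stated time of 72 h (on this read-out lower numbers stand for stronger inhibition and higher numbers for weaker inhibition), compound 1 `CC(=O)N1CCC(S(=O)(=O)c2ccc(CNC(=O)N3Cc4ccncc4C3)cc2)CC1` gives 110 nM while compound 2 `CCC(=O)N1CCC(S(=O)(=O)c2ccc(CNC(=O)N3Cc4ccncc4C3)cc2)CC1` gives 54 nM and so holds the lower of the two numbers. Among the measured compounds shown here, the only measured step of a 2.0-fold lower number from compound 1 to compound 2 (0.31 log units; beyond the scatter) is modest and puts methyl in place of hydrogen on the chain. For the measured compounds named here, compound 3 `O=C(NCc1ccc(S(=O)(=O)N2CCC(O)CC2)cc1)N1Cc2ccncc2C1` has 4-hydroxypiperidin-1-yl in place of 1-propanoylpiperidin-4-yl on a sulfonyl sulfur and no measured step covers so large a swap. Going by the values given here, with only that modest step a 2.0-fold lower number from compound 1 to compound 2 (0.31 log units; beyond the scatter) as a weak guide, a small rise is expected, the estimated change being a 2.2-fold higher number from compound 2 to compound 3 (0.35 log units; beyond the scatter) with wide uncertainty. Compound 3 is expected at 120 nM with an estimated range of 25 nM to 500 nM in this read-out.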

Compound 3, half-maximal inhibitory concentration: 98 nM
Compound 3: middle estimate off by 1.2-fold (0.09 log units), on the high side, and the stated range covers the measured number.
By their numbers in this assay, from the lowest: compounds 2, 3 and 1 (each within the scatter of the next, the first and the last beyond it).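

In this assay, 4-hydroxypiperidin-1-yl on the sulfonyl sulfur gives a 1.8-fold higher number from compound 2 to compound 3 (0.26 log units; within the scatter) and a 1.1-fold lower number from compound 1 to compound 3 (0.05 log units; within the scatter) in place of the two acylated piperidines. A much larger swap than the earlier methyl step therefore leaves the number within the scatter of both, even though the entering group carries a hydrogen-bond donor and fewer heavy atoms. Nothing shown explains this result. Open, as far as these compounds go, is whether an amine or a carboxylic acid in place of the hydroxyl would hold the number. Also open, from the compounds shown here alone, is how a butanoyl chain would compare with propanoyl.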